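The source may hold more compounds than are shown below. What is called first, only, known or untested is meant among the compounds shown, and "the series" means these compounds.

Measured in an ADME assay on Vero 76 cells (Chlorocebus sabaeus) for cytotoxicity, read by crystal violet staining, with a stated time of 96 h; a higher number here means that more compound is tolerated, a lower number that less compound is tolerated:
- compound 1 `O=[N+]([O-])c1ccc(NC(=S)Nc2cccc(C(F)(F)F)c2)cc1`: 10000 nM
- compound 2 `COc1cccc(NC(=S)Nc2cccc(C(F)(F)F)c2)c1`: 20000 nM

Compound 2 sits within the scatter of compound 1, so these two numbers do not separate the compounds. Compound 3 `FC(F)(F)c1cccc(NC(=S)Nc2ccccc2)c1` is the next to be read in this assay. It has hydrogen in place of methoxy on an aromatic carbon.

Within the data shown here, no measured pair differs in one place, so no direct precedent exists for this change. Among the measured compounds shown here, the only guide is that compound 1 at 10000 nM and compound 2 at 20000 nM carry different groups yet remain within the scatter of each other. On that thin basis, no step beyond the scatter is expected, in either direction. The estimated step is no change at the digits printed from compound 2 to compound 3 (within the scatter). The expected value for compound 3 is 20000 nM, with an estimated range of 8000 nM to 50000 nM.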

Compound 3, half-maximal cytotoxic concentration: 39000 nM
For compound 3 the middle estimate is 2.0-fold (0.29 log units) below the measured one, within the range that was stated.
By their numbers in this assay, from the lowest: compounds 1, 2 and 3 (each within the scatter of the next, the first and the last beyond it).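

In this assay, hydrogen in place of methoxy gives a 2.0-fold higher number from compound 2 to compound 3 (0.29 log units; within the scatter), so at this position, meta to a large group, the two are not separated by this read-out. Hydrogen in place of nitro gives a 3.9-fold higher number from compound 1 to compound 3 (0.59 log units; beyond the scatter), the first single-place step in the series to clear the scatter, though only modestly, and it shows that more compound is tolerated without the nitro group. Nothing available on these compounds speaks to what lies behind either step.

As far as these compounds go, whether an amine, a carboxylic acid or a chlorine on the same ring would give a step beyond the scatter remains open. The trifluoromethyl group is common to all three compounds, so its contribution to the tolerated concentration cannot be judged from them.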